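The source may report more compounds than this note shows. Statements on the series, on what has been measured and on what is new or still open speak of the compounds shown alone.

Measured so far in a functional assay on HeLa cells (Homo sapiens) for antiproliferative activity, read by resazurin assay; on this read-out higher numbers stand for weaker inhibition and lower numbers for stronger inhibition:
- compound 1 `CCSC(=S)SCC(=O)c1ccccc1`: 5010 nM
- compound 2 `CCSC(=S)SC(C)C(=O)c1ccccc1`: 5010 nM
- compound 3 `CC(C)SC(=S)SCC(=O)c1ccc(Cl)c(Cl)c1`: 25100 nM

Compound 1 and compound 2 share one core and differ only by hydrogen in place of methyl on a saturated chain carbon bound to a carbonyl carbon and a sulfur. In this assay this gave no change at the digits printed from compound 2 to compound 1 (within the scatter), so at that place the methyl makes no difference to the read-out that can be separated from repeat scatter.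

Compound 3 carries a different core from compound 2; the difference between the two cores is not broken down here. In this assay compound 3 gives the highest number of the three, and its gap to both compound 1 and compound 2 lies beyond the scatter.

Compound 4 `CCSC(=S)SCC(=O)c1ccc(Cl)c(Cl)c1` is not yet measured. It is obtained from compound 3 by hydrogen in place of methyl on a saturated chain carbon bound to a saturated chain carbon and a sulfur. Going by the values given here, this is the same kind of change as the one from compound 2 to compound 1, but not the same: there the carbon losing the methyl was bound to a carbonyl carbon and a sulfur, here it is bound to a saturated chain carbon and a sulfur. Among the compounds with values here, the only direct precedent is thus on a neighbouring position of a different core, and it showed nothing. The expectation for compound 4 is therefore a flat step, a 1.1-fold lower number from compound 3 to compound 4 (0.06 log units; within the scatter), resting on no change at the digits printed from compound 2 to compound 1 (within the scatter) as the nearest comparison. Compound 4 is estimated at 22000 nM in this assay, with a plausible range from 8000 nM to 60000 nM, the width reflecting that the two places are not identical.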

Compound 4, half-maximal inhibitory concentration: 7940 nM
Beside the measured number, compound 4's estimate is 2.8-fold (0.44 log units) above it; measured number below the stated range.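

In this assay, going from isopropyl to ethyl gives a 3.2-fold lower number from compound 3 to compound 4 (0.50 log units; beyond the scatter), a modest step, so the flat result seen earlier for hydrogen in place of methyl does not carry over to this pair: the same change on two cores in this assay, no change at the digits printed (within the scatter) from compound 2 to compound 1 and a 3.2-fold lower number (0.50 log units; beyond the scatter) from compound 3 to compound 4, 3.2-fold (0.50 log units) apart, beyond the scatter of two such steps. This comparison does not isolate the core, as the carbon losing the methyl is bound to a carbonyl carbon and a sulfur in no change at the digits printed from compound 2 to compound 1 (within the scatter), but to a saturated chain carbon and a sulfur in the new step, so core and place change together. Going by these compounds alone, with a single pair on each side, the result shows only that this change cannot be carried between these cores as a fixed step; it does not show whether core or place sets the gap, or why the gap arises.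

Still open, on these data alone, is whether a longer chain such as butyl in place of the ethyl would extend, hold or reverse the step seen on going from isopropyl to ethyl. Also open, as far as these compounds go, is how this assay would respond to an amine or a carboxylic acid at the end of that chain, on either core.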